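Oxazolyl Analogue of a Microsomal Half-Life Series

The source may report more compounds than this note shows. Statements on the series, on what has been measured and on what is new or still open speak of the compounds shown alone.

Compound 1 `CC(C)C(c1ncc[nH]1)c1ccc(-c2ccc3cccc(F)c3c2)[nH]c1=O`: < 0.0667 h
Compound 2 `CC(C)NC(=O)CC(c1ccc(-c2ccc3cccc(F)c3c2)[nH]c1=O)C(C)C`: < 0.0667 h
Compound 3 `CC(C)C(/C=C1\CCNC1=O)c1ccc(-c2ccc3cccc(F)c3c2)[nH]c1=O`: 0.345 h

In an ADME assay on microsomes from liver (Rattus norvegicus) for metabolic stability (on this read-out higher numbers stand for a longer-lived compound and lower numbers for a shorter-lived compound), compound 1 gives only a limit, < 0.0667 h. In this assay compound 2 likewise gives only a limit, < 0.0667 h. Compound 3 gives 0.345 h, and the step of an at least 5.1-fold higher number from compound 2 to compound 3 (0.71 log units; beyond the scatter) is readable, while a step that the two limits leave unreadable from compound 1 to compound 2 is not. Compound 4 `CC(C)C(c1ncco1)c1ccc(-c2ccc3cccc(F)c3c2)[nH]c1=O` carries 1,3-oxazol-2-yl in place of (isopropylcarbamoyl)methyl on a saturated chain carbon bound to an aromatic carbon and a saturated chain carbon. The change brings in a five-membered aromatic ring with two hetero atoms, as in compound 1, which sits at the same limit (the limit of < 0.0667 h in this assay, at which 2 of the 3 values shown sit). Compound 4 is therefore expected to stay near that limit, with the step that the limit leaves unreadable from compound 2 to compound 4 not beyond the scatter. Compound 4 is estimated at 0.05 h, between 0.02 h and 0.15 h.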

Compound 4, half-life: 0.0983 h
Beside the measured number, compound 4's estimate is 2.0-fold (0.29 log units) below it, and the stated range covers the measured number.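

On a saturated chain carbon bound to an aromatic carbon and a saturated chain carbon, 1,3-oxazol-2-yl gives a readable number in this assay, with an at least 1.4-fold higher number from compound 1 to compound 4 (0.16 log units; that floor lies within the scatter) and an at least 1.4-fold higher number from compound 2 to compound 4 (0.16 log units; that floor lies within the scatter). The group carried by compound 3 still gives the longer half-life, with a 3.5-fold lower number from compound 3 to compound 4 (0.55 log units; beyond the scatter). The true size of the first two steps stays unknown, since each starts from a limit: the limit of < 0.0667 h in this assay, at which 2 of the 4 values shown sit.

The compounds shown leave open how a 1,3-thiazol-2-yl group or a carboxylic acid on this carbon would compare with compound 3 and compound 4.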